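The source may report more compounds than this note shows. Statements on the series, on what has been measured and on what is new or still open speak of the compounds shown alone.

Measured so far:
- compound 1, `O=C(NCc1ccc(F)cc1)c1nc(Br)c2cccnc2c1N1CCNCC1`: > 10000 nM in a functional assay on HCT-116 cells (Homo sapiens) for cytotoxicity, read by MTT assay, with a stated time of 72 h; on this read-out lower numbers stand for stronger inhibition and higher numbers for weaker inhibition
- compound 2, `NCCCCCCNc1c(C(=O)NCc2ccc(F)cc2)nc(Br)c2cccnc12`: 7000 nM in this assay

The value of compound 1 is a limit of this assay, not a number; compound 1 therefore stands only at a bound, with no measured position beyond it. Among the measured compounds shown here, the single measured step, an at least 1.4-fold lower number from compound 1 to compound 2 (0.15 log units; that floor lies within the scatter), rests on that limit of > 10000 nM in this assay, at which 1 of the 2 values shown sits, and is within the scatter, so it sets no direction of its own.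

Compound 3, `CC(C)(C)OC(=O)N1CCN(c2c(C(=O)NCc3ccc(F)cc3)nc(Br)c3cccnc23)CC1`, differs from compound 1 by tert-butoxycarbonyl in place of hydrogen on an amine nitrogen in a ring. For the measured compounds named here, no measured step touches this change: the step from compound 1 to compound 2 replaces the whole ring amine, whereas here the ring is kept and only its hydrogen is exchanged for tert-butoxycarbonyl. The series gives no size or direction for such a step. Compound 3 is therefore expected to remain near the bound of compound 1, with a step that the limit leaves unreadable from compound 1 to compound 3 expected to fall within the scatter.

Compound 3 is estimated at 12000 nM in this assay, with a range of 3000 nM to 50000 nM.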

Compound 3, half-maximal inhibitory concentration: > 10000 nM
Compound 3 ended at the assay's limit; the forecaster's own chance of this, stated with the estimate: 60%; the middle value lies beyond the limit too.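

Compound 1 and compound 3 both stand at a limit in this assay, not at a number, so no step between them can be read: the limit of > 10000 nM in this assay, at which 2 of the 3 values shown sit.

Going by these compounds, whether tert-butoxycarbonyl in place of hydrogen on an amine nitrogen in a ring changes the read-out at all remains open.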